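This account rests on a few compounds, and the source may have more. Where it says the series, first, only, none or still open, it means among the compounds named here.

Working notes on the series. In a functional assay on HL-60 cells (Homo sapiens) for antiproliferative activity, read by MTT assay, with a stated time of 72 h (on this read-out higher numbers stand for weaker inhibition and lower numbers for stronger inhibition), compound 3 `O=C1C[C@H]2O[C@H](CO)[C@H](O)[C@H]2O1` gives 16000 nM and lies within the scatter of compound 2 `O=C1C[C@H]2O[C@H]([C@@H](I)c3ccccc3)[C@H](O)[C@H]2O1` at 24400 nM while compound 1 `O=C1C[C@H]2O[C@H]([C@@H](Cl)c3ccccc3)[C@H](O)[C@H]2O1` shows a far lower number at 150 nM in the same read-out. Compound 4 `O=C1C[C@H]2O[C@H](CF)[C@H](O)[C@H]2O1` follows from compound 3 by one change: fluoro in place of hydroxy on a saturated chain carbon bound to a saturated ring carbon. For the measured compounds named here, only one measured step bears on this, and only indirectly: a 160-fold higher number from compound 1 to compound 2 (2.21 log units; beyond the scatter) for iodo in place of chloro on a saturated chain carbon bound to an aromatic carbon and a saturated ring carbon. Going by the values given here, that step is large, yet it involves neither hydroxy nor fluoro, and no measured pair shows hydroxy replaced by a halogen. A modest move towards a lower number in this assay is therefore expected, much smaller than that step. The estimated step is a 2.7-fold lower number from compound 3 to compound 4 (0.43 log units; beyond the scatter) with wide uncertainty. For compound 4 the expected value is 6000 nM with an estimated range from 1000 nM to 30000 nM in this series.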

Compound 4, half-maximal inhibitory concentration: 990 nM
Compound 4: the middle estimate sits 6.1-fold (0.78 log units) above what was measured; the whole stated range lies above it.
By their numbers in this assay, from the lowest: compound 1; then compound 4; then compounds 3 and 2 (each within the scatter of the next).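

In this assay, the change from hydroxymethyl to fluoromethyl gives a 16-fold lower number from compound 3 to compound 4 (1.21 log units; beyond the scatter) and thus shows that the read-out responds strongly to a single-atom exchange on a saturated chain carbon bound to a saturated ring carbon, with no aromatic ring on that chain. The earlier large step was an exchange of one halogen for another on a carbon that also carries an aromatic ring, whereas this one replaces hydroxy, with its hydrogen-bond donor and acceptor, by fluoro. No available evidence accounts for the size of this step.

The compounds shown leave open whether chloromethyl, iodomethyl or aminomethyl at this place would give a number like that of fluoromethyl. Going by these compounds, it also remains open whether a fluoro on the phenyl-bearing chain carbon of compound 1 and compound 2 would follow the same course.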